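The compounds below may be only part of what the source reports. "The series", "measured", "known", "first", "only" and "open" are said of these compounds alone.

Compound 1 `CCOc1ccc(Br)cc1-c1cc(Nc2cccc(C#N)c2)nc(N)n1`: > 1000 nM
Compound 2 `CCOc1ccc(Br)cc1-c1cc(Nc2ccc(/C(C)=N\O)cc2)nc(N)n1`: < 50 nM
Compound 3 `Cc1ccc(Cl)cc1-c1cc(Nc2ccc(Br)cc2)nc(N)n1`: 130 nM

All three were read out in a functional assay on DU-145 cells (Homo sapiens) for inhibition; on this read-out higher numbers stand for weaker inhibition and lower numbers for stronger inhibition. Compound 2 gives < 50 nM, which is a limit and not a number. Compound 1 gives > 1000 nM, also a limit. Compound 3 gives a numerical value of 130 nM.

Compound 4 `CCOc1ccc(Br)cc1-c1cc(Nc2ccc(Cl)cc2)nc(N)n1` is not yet measured. It differs from compound 2 by one chlorine atom in place of a group of 4 heavy atoms (2 carbon, 1 nitrogen, 1 oxygen; no ring), on an aromatic carbon. For the measured compounds named here, no measured pair isolates this change. The closest guide is compound 3 at 130 nM, which also carries a halogen on that ring. The step of an at least 3.0-fold higher number from compound 2 to compound 4 (0.47 log units; beyond the scatter) is expected to go towards weaker inhibition and beyond the scatter. For compound 4 the estimated value in this assay is 150 nM, with an expected range of 50 nM to 600 nM.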

Compound 4, half-maximal inhibitory concentration: 80 nM
Compound 4: the middle estimate sits 1.9-fold (0.27 log units) above what was measured; the range from low to high includes it.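

In this assay, chloro on this aromatic carbon, para to a large group, gives an at least 1.6-fold higher number from compound 2 to compound 4 (0.20 log units; that floor lies within the scatter), so no real loss against the larger group is established. The true size of this step stays unknown because compound 2 sits at a limit: the limit of < 50 nM in this assay, at which 1 of the 4 values shown sits.
With 4-chlorophenyl in place of 3-cyanophenyl on the nitrogen, the series shows an at least 12-fold lower number from compound 1 to compound 4 (1.09 log units; beyond the scatter), a large step measured against a limit: the limit of > 1000 nM in this assay, at which 1 of the 4 values shown sits.

Open, on these data alone, is how an amine or a carboxylic acid on this carbon would compare with chloro. Also open, as far as these compounds go, is whether a 4-cyanophenyl group would keep the inhibition of compound 4.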